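Halogen position on the arylidene: compound 3 to compound 4

The compounds below may be only part of what the source reports. "The series", "measured", "known", "first", "only" and "open" are said of these compounds alone.

Measured so far in a functional assay on KB cells (Homo sapiens) for cytotoxicity, read by MTT assay, with a stated time of 72 h; a higher number here means that more compound is needed for the effect, a lower number that less compound is needed:
compound 1 `O=C1/C(=C\c2ccc(F)cc2)c2ccccc2N1c1c(Cl)cccc1Cl` — 5 ug/mL
compound 2 `O=C1/C(=C\c2cccc(Br)c2)c2ccccc2N1c1c(Cl)cccc1Cl` — 2 ug/mL
compound 3 `O=C1/C(=C\c2ccccc2Cl)c2ccccc2N1c1c(Cl)cccc1Cl` — 5 ug/mL

Within the data shown here, compound 3 stands level with compound 1 at the digits printed, the two together giving the highest numbers of the three; its only step beyond the scatter is a 2.5-fold higher number from compound 2 to compound 3 (0.40 log units; beyond the scatter). Compound 1 and compound 3 agree, as no change at the digits printed from compound 1 to compound 3 (within the scatter) shows, while compound 2 sits apart by a 2.5-fold lower number from compound 1 to compound 2 (0.40 log units; beyond the scatter).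

Compound 4 `O=C1/C(=C\c2ccc(Cl)cc2)c2ccccc2N1c1c(Cl)cccc1Cl` differs from compound 3 in one place: 4-chlorophenyl in place of 2-chlorophenyl on a double-bonded chain carbon bound to a double-bonded ring carbon. Among the measured compounds shown here, no measured pair carries a chlorine from one position to another on this aryl group, so no step bears directly. What is known is that 4-fluorophenyl in compound 1 and 2-chlorophenyl in compound 3 land at the same number, and only 3-bromophenyl in compound 2 moves the value. The expectation is therefore a step within the scatter, a 1.3-fold lower number from compound 3 to compound 4 (0.10 log units; within the scatter), in no firm direction. Compound 4 is estimated at 4 ug/mL, with a range from 1.5 ug/mL to 10 ug/mL.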

Compound 4, concentration for half-maximal effect: 2 ug/mL
For compound 4 the middle estimate is 2.0-fold (0.30 log units) above the measured one, within the range that was stated.
By their numbers in this assay, from the lowest: compounds 2 and 4 (each within the scatter of the next); then compounds 1 and 3 (each within the scatter of the next).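

At the place on a double-bonded chain carbon bound to a double-bonded ring carbon, the position of the halogen matters: with chlorine kept, 4-chlorophenyl in place of 2-chlorophenyl gives a 2.5-fold lower number from compound 3 to compound 4 (0.40 log units; beyond the scatter) in this assay. The identity of the halogen also registers, since chloro in place of fluoro on an aromatic carbon gives a 2.5-fold lower number from compound 1 to compound 4 (0.40 log units; beyond the scatter), whereas 4-chlorophenyl in place of 3-bromophenyl gives no change at the digits printed from compound 2 to compound 4 (within the scatter), so a 2-chlorophenyl or 4-fluorophenyl group is not matched by every halogenated aryl group here. No available data account for these steps.

Going by these compounds, how 3-chlorophenyl and 4-bromophenyl would compare remains open, so the effects of halogen and position are not yet separated. Also open, on these data alone, is whether a halogen is needed at all, which an amine, a methoxy group or a carboxylic acid on this phenyl ring would test.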